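Removing a Hydroxy Group from a Triazole Cytotoxic Series

The source may report more compounds than this note shows. Statements on the series, on what has been measured and on what is new or still open speak of the compounds shown alone.

Of the compounds shown here, three have been tested in a functional assay on MDA-MB-231 cells (Homo sapiens) for cytotoxicity, read by MTT assay; on this read-out higher numbers stand for weaker inhibition and lower numbers for stronger inhibition. Compound 1, `COc1ccc(-c2cn(-c3ccc(OC(F)(F)F)cc3)nn2)cc1`, gives 1000 nM. Compound 3, `COc1ccc(-n2cc(-c3ccc(OC)c(OC)c3)nn2)cc1`, reaches only a limit of the assay, > 100 nM, and not a number. Compound 2, `COc1ccc(-n2cc(-c3cc(O)cc(O)c3)nn2)cc1O`, likewise reaches only a limit, > 10000 nM, so no number stands for it. Among the three values shown, compound 2 therefore sits at the limit of > 10000 nM in this assay, at which 1 of the 3 values shown sits, while one further value, that of compound 3, sits at the limit of > 100 nM in this assay, at which 1 of the 3 values shown sits; only compound 1 carries a measured figure.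

Compound 4, `COc1ccc(-n2cc(-c3cc(O)cc(O)c3)nn2)cc1`, has not yet been measured. It differs from compound 2 in one place: hydrogen in place of hydroxy on an aromatic carbon. The change sits on an aromatic carbon of a six-membered aromatic ring of carbon only, ortho to a methoxy group and meta to a large group.

Among the compounds with values here, no step between two measured compounds is available to show what this change does. Since compound 2 reaches only a limit, > 10000 nM, a strong gain would be needed before a number appears. Compound 4 is expected near 8000 nM, with a likely range from 2000 nM to 30000 nM. The expected step of an at least 1.2-fold lower number from compound 2 to compound 4 (0.09 log units; that floor lies within the scatter) is estimated to stay within the usual scatter, and a limit may again be reported.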

Compound 4, half-maximal inhibitory concentration: > 10000 nM
Compound 4: a limit, no number; the forecaster's own chance of this, stated with the estimate: 50%; middle value at least 1.2-fold (0.09 log units) from the limit.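

In this assay compound 4 gives > 10000 nM as a limit of the assay and not a number. Compound 2 also stands at a limit, so the step between compound 2 and compound 4 cannot be read. The compounds shown leave open whether swapping hydroxy for hydrogen at this place changes cytotoxicity at all.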